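This account rests on a few compounds, and the source may have more. Where it says the series, first, only, none or still open, it means among the compounds named here.

Compound 3 `CCCn1c(=O)n(CCN(C)C)c(=O)c2[nH]cnc21` stands second highest of the three numbers in a functional assay (trachea) with Cavia porcellus as the target (a lower number here means that less compound is needed, a higher number that more compound is needed for the effect), giving 2700 nM. Compound 1 `C=CCCn1c(=O)c2[nH]cnc2n(CCC)c1=O` gives 200 nM, and compound 2 `CCCn1c(=O)n(CC(=O)O)c(=O)c2[nH]cnc21` gives 41000 nM. Compound 4 `CCCn1c(=O)n(CCOCC)c(=O)c2[nH]cnc21` differs from compound 3 by ethoxy in place of dimethylamino on a saturated chain carbon, two bonds along the chain from an aromatic nitrogen. The step that bears most on this change is a 14-fold higher number from compound 1 to compound 3 (1.13 log units; beyond the scatter), since it sits at the same place; the steps of a 210-fold higher number from compound 1 to compound 2 (2.31 log units; beyond the scatter) and a 15-fold lower number from compound 2 to compound 3 (1.18 log units; beyond the scatter) sit on the carbon bound to the aromatic nitrogen and carry less weight. Because compound 1 gives 200 nM with vinyl at that place, a downward step of about a 3.4-fold lower number from compound 3 to compound 4 (0.53 log units; beyond the scatter) is expected for compound 4, though smaller than the full return to compound 1. Compound 4 is therefore estimated at 800 nM, within 250 nM to 3000 nM.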

Compound 4, half-maximal effective concentration: 70 nM
The estimate for compound 4 lay 11-fold (1.06 log units) above the measured number; measured number below the stated range.
By their numbers in this assay, from the lowest: compound 4; then compound 1; then compound 3; then compound 2.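

In this assay, swapping dimethylamino for ethoxy keeps the heavy-atom, donor and acceptor counts and the lack of net charge, yet gives a 39-fold lower number from compound 3 to compound 4 (1.59 log units; beyond the scatter), so these counts alone do not set the number at this place. Ethoxy also goes past the vinyl of the butenyl chain, with a 2.9-fold lower number from compound 1 to compound 4 (0.46 log units; beyond the scatter), and the widest step in the series is a 590-fold lower number from compound 2 to compound 4 (2.77 log units; beyond the scatter). Nothing available accounts for these steps.

Open, from the compounds shown here alone, is whether the ether oxygen itself matters, which a hydroxyl or methoxy at this place would help to test. Also open, going by these compounds, is how a longer alkoxy chain, such as propoxy, would compare.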